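Deoxycytidine kinase inhibition: shortening the chain of compound 2

A few compounds are considered here, and "the series" means these few. Any claim that something is new, unique, unknown or untested is made for them only; others in the source may bear on it.

Measured so far:
- compound 1, `CCCCCCCCOc1nccc(N)n1`, 1000000 nM
- compound 2, `CC(C)CCn1ccc(N)nc1=O`, 5000000 nM
- compound 3, `Nc1ccnc(SCCCOc2ccccc2)n1`, 2000000 nM

All three numbers come from an assay on isolated protein for inhibition of deoxycytidine kinase (Rattus norvegicus); a lower number here means a stronger inhibitor, a higher number a weaker inhibitor. Among them compound 2 stands highest, meaning it is the weakest of the three. The nearest number is that of compound 3, which lies lower by a gap beyond the scatter; the furthest is that of compound 1, lower by a gap that is also beyond the scatter. Among the measured compounds shown here, no two compounds in the set differ in only one place, so no single structural step has a measured size yet.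

For the measured compounds named here, compound 4, `CCCn1ccc(N)nc1=O`, is the first such step: it differs from compound 2 by methyl in place of isopropyl on a saturated chain carbon, two bonds along the chain from an aromatic nitrogen. In chain terms the change reads isobutyl to ethyl. Nothing measured tells how this assay responds to a shorter chain at this position; the two lower numbers in the set, compound 1 and compound 3, both carry longer chains than compound 2, but they differ from it in more than one place and cannot fix the size of this step.

The expectation is therefore a step of a 1.4-fold higher number from compound 2 to compound 4 (0.15 log units; within the scatter), toward a weaker or unchanged inhibitor rather than a stronger one. Compound 4 is estimated at 7000000 nM, with a range from 2000000 nM to 25000000 nM.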

Compound 4, half-maximal inhibitory concentration: 12000000 nM
Beside the measured number, compound 4's estimate is 1.7-fold (0.23 log units) below it, and the stated range covers the measured number.
By their numbers in this assay, from the lowest: compounds 1 and 3 (each within the scatter of the next); then compound 2; then compound 4.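

In this assay, among the compounds shown here, the change gives a 2.4-fold higher number from compound 2 to compound 4 (0.38 log units; beyond the scatter), so the saturated chain carbon two bonds along the chain from an aromatic nitrogen is the first place where a single change has a measured size. The direction is toward a weaker inhibitor: compound 2 with its isobutyl chain gives 5000000 nM, and compound 4 with its ethyl chain gives 12000000 nM, which shows that the shorter chain does not hold the level of the longer one, although the step is modest. Nothing on hand accounts for the size or direction of this step.

A single step in one direction does not settle whether a longer straight chain such as hexyl would lower the number at this position, or whether the step follows from chain length or from the loss of the branched isopropyl end. Also open, on these data alone, is how this position responds to a chain ending in an amine or a carboxylic acid, and whether any such chain would bring the number down.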